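The source may hold more compounds than are shown below. What is called first, only, known or untested is meant among the compounds shown, and "the series" means these compounds.

Of the compounds shown here, three share one core and have been measured in a functional assay for antagonist activity at Alpha-1A adrenergic receptor (Oryctolagus cuniculus); on this read-out higher numbers stand for weaker binding and lower numbers for tighter binding. Compound 1 `COc1ccccc1N1CCN(CCCNc2ncccc2C(=O)N(C)C)CC1` gives 1.59 nM. Compound 2 `CN(C)C(=O)c1cccnc1NCCCN1CCN(c2ccccc2O)CC1` gives 5.01 nM. Compound 3 `Cc1ccccc1N1CCN(CCCNc2ncccc2C(=O)N(C)C)CC1` gives 2 nM. The step of a 3.2-fold higher number from compound 1 to compound 2 (0.50 log units; beyond the scatter) and the step of a 2.5-fold lower number from compound 2 to compound 3 (0.40 log units; beyond the scatter) both lie beyond the scatter, while the step of a 1.3-fold higher number from compound 1 to compound 3 (0.10 log units; within the scatter) does not. Compound 3 thus stands second highest of the three numbers, indistinguishable from compound 1 and clearly below compound 2.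

Compound 4 `CN(C)C(=O)c1cccnc1NCCCN1CCN(c2ccccc2C2CC2)CC1` is the next step from compound 3: cyclopropyl in place of methyl on an aromatic carbon. The two steps that touch the same aromatic carbon are the small one from compound 1 to compound 3 and the modest one from compound 2 to compound 3. Neither involves a cyclopropyl, so they set only a loose frame: swaps at this place have moved this assay by little or by a modest amount, without a clear direction for a larger carbon group. For compound 4 the expected step is a 1.3-fold higher number from compound 3 to compound 4 (0.10 log units; within the scatter), within the scatter. Compound 4 is therefore estimated at 2.5 nM, with a range from 1 nM to 6.3 nM.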

Compound 4, dissociation constant: 0.631 nM
For compound 4 the middle estimate is 4.0-fold (0.60 log units) above the measured one; measured number outside the range, below it.
By their numbers in this assay, from the lowest: compound 4; then compounds 1 and 3 (each within the scatter of the next); then compound 2.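

Earlier swaps on this aromatic carbon separated only hydroxy from methoxy and methyl, and the last two could not be told apart. Compound 4 adds the first sign that a larger carbon group here, ortho to a large group, can lower the number in this assay: going from methyl, with 1 heavy atom, to cyclopropyl, with 3, gives a 3.2-fold lower number from compound 3 to compound 4 (0.50 log units; beyond the scatter). Cyclopropyl also stands clear of the other two groups, with a 2.5-fold lower number from compound 1 to compound 4 (0.40 log units; beyond the scatter) and a 7.9-fold lower number from compound 2 to compound 4 (0.90 log units; beyond the scatter), which leaves compound 4 with the lowest number of the four.

Open, going by these compounds, is whether an isopropyl, a tert-butyl or a cyclobutyl on this carbon would lower the number further or raise it again, and so whether the ring or simply the added carbons matter. Nothing measured here explains why the number falls.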